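One More Methoxy on the Lower-Valued Compound

The source may report more compounds than this note shows. Statements on the series, on what has been measured and on what is new or still open speak of the compounds shown alone.

Going by the values given here, in a functional assay on CNE-2 cells (Homo sapiens) for antiproliferative activity, read by sulforhodamine B assay, with a stated time of 48 h (on this read-out lower numbers stand for stronger inhibition and higher numbers for weaker inhibition), compound 1 (`COc1ccc(-c2ccccc2C(=O)/C=C/c2ccc(F)cc2)cc1OC`) gives 5400 nM, while compound 2 (`COc1ccc(/C=C/C(=O)c2ccccc2-c2ccc(OC)c(OC)c2)cc1`) gives 320 nM, the lowest of the two numbers so far. Compound 3 (`COc1ccc(/C=C/C(=O)c2ccccc2-c2ccc(OC)c(OC)c2)cc1OC`) has not yet been measured. It differs from compound 2 by one change: methoxy in place of hydrogen on an aromatic carbon. This is methoxy in place of hydrogen on an aromatic carbon, which turns 4-methoxyphenyl into 3,4-dimethoxyphenyl.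

Among the compounds with values here, only one measured step bears on this change: a 17-fold lower number from compound 1 to compound 2 (1.23 log units; beyond the scatter). That step is large and beyond the scatter, and it also brought in a methoxy group, but in place of fluoro rather than hydrogen. It therefore shows that a swap on this aromatic group can shift the number in this assay, yet it does not show what an added methoxy will do. Within the data shown here, no measured pair tests that addition, so no firm direction is expected, and the expected change stays within the scatter. The estimated step is a 1.3-fold higher number from compound 2 to compound 3 (0.10 log units; within the scatter). Compound 3 is expected to give about 400 nM, with an estimated range from 100 nM to 1600 nM.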

Compound 3, half-maximal inhibitory concentration: 2500 nM
Compound 3: the middle estimate sits 6.3-fold (0.80 log units) below what was measured, outside the stated range (above it).
By their numbers in this assay, from the lowest: compound 2; then compound 3; then compound 1.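

In this assay, this small addition matters: turning 4-methoxyphenyl into 3,4-dimethoxyphenyl gives a 7.8-fold higher number from compound 2 to compound 3 (0.89 log units; beyond the scatter), so this aromatic carbon, which carries only a hydrogen in compound 2, does not tolerate a methoxy without a clear loss. The earlier step might have suggested that methoxy groups on this ring simply lower the number, but the three compounds do not follow that simple pattern: compound 2 gains over compound 1 with one methoxy, while compound 3, with a second methoxy, gives up most of that gain and keeps only a 2.2-fold lower number from compound 1 to compound 3 (0.33 log units; beyond the scatter). Nothing measured on these compounds gives a reason for the rise.

The compounds shown leave open whether a hydroxyl or a chlorine at this same place would raise the number as methoxy does, and whether an ethoxy would raise it further. They also leave open how much the low number of compound 2 depends on the other 3,4-dimethoxyphenyl group, which stays the same in all three compounds.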